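Compound 2 to compound 3: removing the methoxycarbonyl group

This account rests on a few compounds, and the source may have more. Where it says the series, first, only, none or still open, it means among the compounds named here.

The series rests on a shared core, seen in compound 1 (`C/C=C/C(=O)Nc1ccccc1`) and compound 2 (`COC(=O)CN(C)C/C=C/C(=O)Nc1ccccc1`). In an ADME assay for pharmacokinetics, read by LC-MS, in phosphate buffer, with a stated time of 120 min, at pH 7.4, tested at 1 uM, in the presence of a further agent that is not named here (on this read-out lower numbers stand for a shorter-lived compound and higher numbers for a longer-lived compound), compound 1 gives > 8.53 h, which is a limit and not a number. In this assay compound 2 gives > 8.53 h, which is also a limit. The measured picture so far is therefore (the limit of > 8.53 h in this assay, at which 2 of the 2 values shown sit), and compound 2 has no exact position.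

The next compound is compound 3 (`CN(C)C/C=C/C(=O)Nc1ccccc1`). The change from compound 2 is hydrogen in place of methoxycarbonyl on a saturated chain carbon bound to an amine nitrogen, which also reads as (methoxycarbonyl)methyl to methyl.

Among the measured compounds shown here, no measured step gives a size for this change, so the expectation is weakly founded. A modest move towards a shorter-lived compound is expected, though a result within the usual scatter would be no surprise. The estimated change is an at least 1.2-fold lower number from compound 2 to compound 3 (0.08 log units; that floor lies within the scatter). For compound 3 the expected half-life is 7 h, with an estimated range of 2.5 h to 15 h.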

Compound 3, half-life: 1.93 h
Compound 3: the middle estimate sits 3.6-fold (0.56 log units) above what was measured; measured number below the stated range.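

In this assay, among the compounds shown here, this is the first change that moves the read-out off the limit, giving an at least 4.4-fold lower number from compound 2 to compound 3 (0.64 log units; beyond the scatter), and the same compound seen from the shared core, with dimethylamino in place of hydrogen on a saturated chain carbon bound to a double-bonded chain carbon, gives an at least 4.4-fold lower number from compound 1 to compound 3 (0.64 log units; beyond the scatter). The amine nitrogen alone does not go with the lower number, since compound 2 carries it too and stays at the limit, so within these compounds the drop follows the loss of the methoxycarbonyl group, and compound 3 is the only one of the three with an exact value. Both steps are floors and not exact sizes, because their starting values are limits and not numbers: the limit of > 8.53 h in this assay, at which 2 of the 3 values shown sit.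

On these data alone, how far compound 1 and compound 2 lie past that limit stays open, and with it the true size of both steps. Also open, as far as these compounds go, is whether a carboxylic acid in place of the methoxycarbonyl group, or a longer chain in place of methyl on the amine nitrogen, would read close to compound 3 or stay at the limit.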